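Chain length and a limit in the rat

A few compounds are considered here, and "the series" means these few. Any claim that something is new, unique, unknown or untested is made for them only; others in the source may bear on it.

compound 1 `CN1CCN(CCN2CCC(c3cn(-c4ccc(F)cc4)c4ccc(Cl)cc34)CC2)C1=O`: 0.021 umol/kg
compound 2 `O=C1NCCN1CCCCCN1CCC(c2cn(-c3ccc(F)cc3)c3ccc(Cl)cc23)CC1`: 1.5 umol/kg
compound 3 `O=C1NCCN1CCCCN1CCC(c2cn(-c3ccc(F)cc3)c3ccc(Cl)cc23)CC1`: > 2.2 umol/kg (a limit)
compound 4 `O=C1NCCN1CCCCCCN1CCC(c2cn(-c3ccc(F)cc3)c3ccc(Cl)cc23)CC1`: not yet measured

In a functional assay on the whole organism for inhibition, with Rattus norvegicus as the target (a lower number here means that less compound is needed, a higher number that more compound is needed for the effect), compound 3 is known only by a limit, > 2.2 umol/kg. Compound 4 has one change: 2-(2-oxoimidazolidin-1-yl)ethyl in place of 2-oxoimidazolidin-1-yl on a saturated chain carbon, four bonds along the chain from an amine nitrogen in a ring. Here 2-(2-oxoimidazolidin-1-yl)ethyl replaces 2-oxoimidazolidin-1-yl, four bonds along the chain from an amine nitrogen in a ring. The closest guide is an at least 1.4-fold higher number from compound 2 to compound 3 (0.16 log units; that floor lies within the scatter), also a change in chain length. The large steps, a 71-fold higher number from compound 1 to compound 2 (1.85 log units; beyond the scatter) and an at least 100-fold higher number from compound 1 to compound 3 (2.02 log units; beyond the scatter), also remove the 3-methyl-2-oxoimidazolidin-1-yl group, so they bear on this change less directly. No step beyond the scatter is therefore expected in this assay. The estimated step is a step that the limit leaves unreadable from compound 3 to compound 4. For compound 4 the estimate is 2.5 umol/kg, with an expected range of 0.7 umol/kg to 8 umol/kg.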

Compound 4, dose for half-maximal effect: > 2.2 umol/kg
Compound 4 was reported as a limit; the forecaster's own chance of this, stated with the estimate: 40%; the middle value is on the limit's open side.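

In this assay compound 4 is known only by a limit, > 2.2 umol/kg. Lengthening the chain by 2-(2-oxoimidazolidin-1-yl)ethyl in place of 2-oxoimidazolidin-1-yl therefore shows no recovery toward compound 1, with an at least 100-fold higher number from compound 1 to compound 4 (2.02 log units; beyond the scatter), while an at least 1.4-fold higher number from compound 2 to compound 4 (0.16 log units; that floor lies within the scatter) adds little information. The step from compound 3 to compound 4 cannot be read, since both rest on the same ceiling: the limit of > 2.2 umol/kg in this assay, at which 2 of the 4 values shown sit.

Where compound 4 truly lies beyond its limit stays open. So does whether a still longer chain, or an amine in place of the 2-oxoimidazolidin-1-yl ring, would need less compound.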